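This account rests on a few compounds, and the source may have more. Where it says the series, first, only, none or still open, it means among the compounds named here.

Compound 1 `N=C(N)c1ccc(-c2ccc(-c3ccc(F)cc3)o2)o1` and compound 2 `N=C(N)c1ccc(-c2ccc(-c3ccc(Cl)cc3)o2)o1` share one core and differ only in the group sitting on a six-membered aromatic ring of carbon only. In a functional assay on K562 cells (Homo sapiens) for inhibition, read by sulforhodamine B assay, with a stated time of 48 h (a lower number here means a stronger inhibitor of growth, a higher number a weaker inhibitor of growth), compound 1 gives 490 nM, and compound 2 gives 1370 nM. The step of a 2.8-fold lower number from compound 2 to compound 1 (0.45 log units; beyond the scatter) corresponds to fluoro in place of chloro on an aromatic carbon. Compound 3 `N=C(N)c1ccc(-c2ccc(-c3ccc(Cl)cc3)s2)s1` is built on a different core than compound 2; the difference between the two cores is not broken down here. In this assay compound 3 gives 670 nM, a number close to that of compound 1 and lower than that of compound 2. Compound 4 `N=C(N)c1ccc(-c2ccc(-c3ccc(F)cc3)s2)s1` is not yet measured. Among the measured compounds shown here, it differs from compound 3 by fluoro in place of chloro on an aromatic carbon, which is the same change, at the same place, as the one that turns compound 2 into compound 1. The step of a 2.5-fold lower number from compound 3 to compound 4 (0.39 log units; beyond the scatter) is expected to be of similar size, because on the other core the same change gave a 2.8-fold lower number from compound 2 to compound 1 (0.45 log units; beyond the scatter). Compound 4 is therefore estimated at 270 nM in this assay, with a likely range from 120 nM to 650 nM.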

Compound 4, concentration for 50% growth inhibition: 1210 nM
For compound 4 the middle estimate is 4.5-fold (0.65 log units) below the measured one, outside the stated range (above it).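

On the core of compound 3, putting fluoro in place of chloro gives a 1.8-fold higher number from compound 3 to compound 4 (0.26 log units; within the scatter), so in this assay these two values cannot be told apart from ordinary repeat scatter. The gain seen on the core of compound 1 therefore cannot be assumed to carry over to the core of compound 3, as the two steps themselves differ: the same change on two cores in this assay, a 2.8-fold lower number (0.45 log units; beyond the scatter) from compound 2 to compound 1 and a 1.8-fold higher number (0.26 log units; within the scatter) from compound 3 to compound 4, 5.0-fold (0.70 log units) apart, beyond the scatter of two such steps This rests on just two matched pairs in a single assay, so it shows that the effect of this swap depends on the core here, but not which feature of the cores is responsible, nor that the swap truly reverses direction on the core of compound 3.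

As far as these compounds go, only fluoro and chloro appear at this place on the ring, so it remains open how bromo, methyl or methoxy would behave there on each core. Also open is whether a matched pair on a third core would follow either of the two cores shown.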